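This account rests on a few compounds, and the source may have more. Where it says the series, first, only, none or still open, it means among the compounds named here.

Measured compounds, all in a functional assay on HepG2 cells (Homo sapiens) for inhibition, read by MTT assay, with a stated time of 72 h; a lower number here means a stronger inhibitor, a higher number a weaker inhibitor:
Compound 1 `O=c1cc(Cn2cc(CNS(=O)(=O)c3ccc([N+](=O)[O-])cc3)nn2)c2ccc(O)cc2o1`: compound 1 gives only a limit, > 100000 nM.
Compound 2 `O=c1cc(Cn2cc(CSC(=S)N3CCOCC3)nn2)c2ccc(O)cc2o1`: compound 2 gives 99400 nM.
Compound 3 `Cn1c(-c2cn(Cc3cc(=O)oc4cc(O)ccc34)nn2)nc2ccccc21`: compound 3 gives 70700 nM.

Compound 3 carries the lowest number among the two numbers shown, but its gap to compound 2 lies within the scatter, so the two cannot be ranked. For compound 1 the assay reports a limit rather than a number (the limit of > 100000 nM in this assay, at which 1 of the 3 values shown sits).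

Compound 4 `Cc1ccc2c(Cn3cc(-c4nc5ccccc5n4C)nn3)cc(=O)oc2c1` is not yet measured. It differs from compound 3 by methyl in place of hydroxy on an aromatic carbon, a methyl in place of hydroxy on an aromatic carbon. Among the compounds with values here, no measured pair in this set shows the effect of such an exchange, so the size of the step cannot be taken from the data. Given that all measured values cluster near the upper end of the assay range, compound 4 is expected to remain in the same region, with a step from compound 3 to compound 4 of a 1.1-fold higher number from compound 3 to compound 4 (0.05 log units; within the scatter), not expected beyond the scatter. The estimate for compound 4 in this assay is 80000 nM, between 25000 nM and 250000 nM, with a real chance that only a limit is reported.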

Compound 4, half-maximal inhibitory concentration: 900 nM
Compound 4: middle estimate off by 89-fold (1.95 log units), on the high side; the measured number lies below the stated range.
By their numbers in this assay, from the lowest: compound 4; then compounds 3 and 2 (each within the scatter of the next). At a limit, above all of these: compound 1.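

In this assay, the hydroxy on the aromatic carbon proves to be a sensitive place: replacing it with methyl gives a 79-fold lower number from compound 3 to compound 4 (1.90 log units; beyond the scatter), with the rest of the molecule unchanged. The change involves one heavy atom and removes the hydrogen-bond donor and hydrogen-bond acceptor counted for hydroxy, so a single exchange at this place is enough to move the value far from that of the hydroxy parent. Nothing measured here gives a property that would account for this step.

On these data alone, it remains open whether the step reflects the loss of hydroxy or the arrival of methyl; a plain hydrogen, methoxy or chlorine at the same carbon would help separate the two. As far as these compounds go, whether the exchange carries over to the side chains of compound 1 and compound 2 also remains open.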